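This account rests on a few compounds, and the source may have more. Where it says the series, first, only, none or still open, it means among the compounds named here.

Working notes on the series.

Compound 1 `Nc1nc2cc(Cl)c(Cl)cc2n1Cc1ccccc1` is the parent. In a functional assay on KB cells (Homo sapiens) for inhibition (a higher number here means a weaker inhibitor, a lower number a stronger inhibitor), compound 1 gives 170000 nM. Compound 2 `Nc1nc2cc(Cl)c(Cl)cc2n1Cc1cccc(C(F)(F)F)c1` carries the change trifluoromethyl in place of hydrogen on an aromatic carbon and in this assay compound 2 gives 45000 nM; the step is a 3.8-fold lower number from compound 1 to compound 2 (0.58 log units; beyond the scatter). Compound 3 `FC(F)(F)c1cccc(Cn2c(Cl)nc3cc(Cl)c(Cl)cc32)c1` is the second core; how it differs from compound 1 is not broken down here. In this assay compound 3 reaches only the limit > 100000 nM, which is a limit of the assay and not a number, matching (the limit of > 100000 nM in this assay, at which 1 of the 3 values shown sits). The step of an at least 2.2-fold higher number from compound 2 to compound 3 (0.34 log units; beyond the scatter) is therefore known only as a bound.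

Compound 4 `FC(F)(F)c1cc(Cn2c(Cl)nc3cc(Cl)c(Cl)cc32)cc(C(F)(F)F)c1` is not yet measured. It differs from compound 3 by trifluoromethyl in place of hydrogen on an aromatic carbon, the same kind of change as that from compound 1 to compound 2, though here the place is also meta to a trifluoromethyl group. The step from compound 3 to compound 4 in this assay is expected to be an at least 1.2-fold lower number from compound 3 to compound 4 (0.09 log units; that floor lies within the scatter), resting on the step of a 3.8-fold lower number from compound 1 to compound 2 (0.58 log units; beyond the scatter) seen on the first core and on compound 3 sitting at the limit > 100000 nM. For compound 4 the expected value is 80000 nM, between 20000 nM and 300000 nM.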

Compound 4, half-maximal inhibitory concentration: > 100000 nM
Compound 4: no number, only a limit (the forecaster's own chance of this, stated with the estimate: 50%); middle value at least 1.2-fold (0.09 log units) away from the limit.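

In this assay compound 4 reaches only > 100000 nM, which is a limit of the assay and not a number. Compound 3 also sits at a limit, so the step from compound 3 to compound 4 cannot be read: the limit of > 100000 nM in this assay, at which 2 of the 4 values shown sit. From the compounds shown here alone, whether the added trifluoromethyl changes inhibition on the core of compound 3 as it did on the core of compound 1 remains open.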